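The source may hold more compounds than are shown below. What is called first, only, known or untested is meant among the compounds shown, and "the series" means these compounds.

Working notes on the series in a functional assay on the whole organism (strain Wistar) for inhibition, with Rattus norvegicus as the target, read by paw edema, with a stated time of 3 h, at a dose of 10 mg/kg by the oral route; a higher number here means more inhibition at the dose given (going by the name of the read-out), a lower number less inhibition.

Three compounds carry a measured number. Compound 1 `Clc1ccc(-c2nnc(COc3ccc(-c4ccccc4)cc3)o2)cc1` gives 75% in this assay. Among the compounds with values here, compound 2 `Clc1ccc(-c2nnc(COc3ccc(-c4ccccc4)cc3)o2)c(Cl)c1` gives 56.1%; the only change between them is chloro in place of hydrogen on an aromatic carbon, and it moves the number by a number 18.9 percentage points lower from compound 1 to compound 2 (beyond the scatter). Compound 3 `Sc1nnc(COc2ccc(-c3ccccc3)cc2)n1-c1ccc(Cl)cc1`, built on a different five-membered core that carries a sulfanyl group and a 4-chlorophenyl on an aromatic nitrogen, gives 15.9%, the lowest of the three numbers and beyond the scatter from both compound 2 and compound 1.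

Compound 4 `Cc1ccccc1-n1c(S)nnc1COc1ccc(-c2ccccc2)cc1` is not yet measured. It differs from compound 3 by 2-methylphenyl in place of 4-chlorophenyl on an aromatic nitrogen.

Within the data shown here, no measured step swaps one aryl group for another on a ring nitrogen. Among the measured compounds shown here, the only step available, chloro in place of hydrogen on an aromatic carbon, is modest and points downward, and in compound 4 a chlorine leaves rather than enters, so if anything a small rise might be expected; the step of a number 6.1 percentage points higher from compound 3 to compound 4 (within the scatter) is therefore estimated as small and within or close to the scatter. Compound 4 is expected to give about 22% in this assay, within 6% to 40%.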

Compound 4, a percentage reported as inhibition, in the whole organism at one dose (the size of the read-out at that dose, not a potency): 56.8%
The estimate for compound 4 lay 34.8 percentage points below the measured number; the measured number lies above the stated range.
By their numbers in this assay, from the lowest: compound 3; then compounds 2 and 4 (each within the scatter of the next); then compound 1.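

In this assay, the aryl group on the aromatic nitrogen of the five-membered ring proves to be a sensitive position: the change gives a number 40.9 percentage points higher from compound 3 to compound 4 (beyond the scatter), and it is a large step even though 4-chlorophenyl and 2-methylphenyl have the same counts of heavy atoms, hydrogen-bond donors and hydrogen-bond acceptors. Within the data shown here, the only earlier step, a number 18.9 percentage points lower from compound 1 to compound 2 (beyond the scatter), was modest, lay on an aromatic carbon of a different core and gave no reading of this ring nitrogen. Among these compounds, nothing measured here bears on why the swap of aryl groups moves the number so far.

From the compounds shown here alone, the step combines the loss of the chlorine with the arrival of the methyl at a different place on the phenyl ring, and it remains open which of these carries it, or whether a plain phenyl, a 2-chlorophenyl or a 4-methylphenyl on this nitrogen would sit with compound 3 or with compound 4. Also open, going by these compounds, is whether the large step holds with a methylthio group or an amine in place of the sulfanyl group on the same ring.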